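Moving the Hydroxyl Group: Compound 2 to Compound 4

The compounds below may be only part of what the source reports. "The series", "measured", "known", "first", "only" and "open" are said of these compounds alone.

In a functional assay on the whole organism (strain Wistar) for inhibition, with Rattus norvegicus as the target, read by paw edema, with stated times of 30 min and 3 h, at a dose of 0.05 mmol/kg by the oral route (on this read-out higher numbers stand for more inhibition at the one dose given (going by the name of the read-out) and lower numbers for less inhibition), compound 1 `Cc1ccc(C2=NN(c3ccc(S(C)(=O)=O)cc3)C(=O)CC2)cc1` gives 46.7% and compound 3 `CCc1ccc(C2=NN(c3ccc(S(C)(=O)=O)cc3)C(=O)CC2)cc1` gives 46.7%. Compound 2 `Cc1cc(C2=NN(c3ccc(S(C)(=O)=O)cc3)C(=O)CC2)ccc1O` gives 26.6% in this assay, the lowest of the three numbers, and both of its neighbours stand beyond the scatter above it: a number 20.1 percentage points lower from compound 1 to compound 2 (beyond the scatter) and a number 20.1 percentage points higher from compound 2 to compound 3 (beyond the scatter). Compound 4 `Cc1ccc(O)c(C2=NN(c3ccc(S(C)(=O)=O)cc3)C(=O)CC2)c1` differs from compound 2 in one respect: 2-hydroxy-5-methylphenyl in place of 4-hydroxy-3-methylphenyl on a carbon with a double bond to nitrogen. Among the compounds with values here, both measured steps concern the presence of the hydroxyl-bearing ring rather than the position of its groups, so no step speaks directly to this change. The expected step is therefore a number 3.4 percentage points higher from compound 2 to compound 4 (within the scatter), with no shift beyond the scatter foreseen. Compound 4 is estimated to give 30% in this assay, within the range 14% to 48%.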

Compound 4, a percentage reported as inhibition, in the whole organism at one dose (the size of the read-out at that dose, not a potency): 66.6%
Beside the measured number, compound 4's estimate is 36.6 percentage points below it; measured number above the stated range.
By their numbers in this assay, from the lowest: compound 2; then compounds 1 and 3 (each within the scatter of the next); then compound 4.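

In this assay, the same atoms joined differently on this ring give a large step (a number 40 percentage points higher from compound 2 to compound 4 (beyond the scatter)), so among these compounds the arrangement of the hydroxyl and methyl groups matters, not just their presence. The 2-hydroxy-5-methylphenyl group also stands clear of both rings without a hydroxyl (a number 19.9 percentage points higher from compound 1 to compound 4 (beyond the scatter); a number 19.9 percentage points higher from compound 3 to compound 4 (beyond the scatter)), whereas 4-hydroxy-3-methylphenyl stood below them. Nothing available explains this difference. Still open, as far as these compounds go, is whether the hydroxyl alone carries the gain, which 2-hydroxyphenyl without the methyl, or an amine or methoxy in the hydroxyl's place, would test.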